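Working notes: from compound 3 to compound 4

A few compounds are considered here, and "the series" means these few. Any claim that something is new, unique, unknown or untested is made for them only; others in the source may bear on it.

Measured so far:
compound 1 `FC(F)(F)c1cccc(Nc2nc3nonc3nc2Nc2cccc(C(F)(F)F)c2)c1` 700 nM
compound 2 `Cc1cccc(Nc2nc3nonc3nc2Nc2ccccc2F)c1` 1500 nM
compound 3 `COc1cccc(Nc2nc3nonc3nc2Nc2ccccc2F)c1` 830 nM

In an assay on mitochondria from L6 cells (Rattus norvegicus) for activation, with a stated time of 90 min (on this read-out higher numbers stand for an effect only at larger amounts of compound and lower numbers for an effect already at smaller amounts), compound 3 gives 830 nM and stands second highest of the three numbers; compound 1 is nearest and compound 2 furthest, both within the scatter. Compound 4 `Fc1ccccc1Nc1nc2nonc2nc1Nc1cccc(C(F)(F)F)c1` differs from compound 3 by trifluoromethyl in place of methoxy on an aromatic carbon. Within the data shown here, no measured step covers this exchange directly. Among the measured compounds shown here, the one step at this place, a 1.8-fold lower number from compound 2 to compound 3 (0.26 log units; within the scatter), stayed within the scatter, and compound 1, which carries the trifluoromethyl, gives 700 nM, close to compound 3. No step beyond the scatter is therefore expected in this assay. Compound 4 is estimated at 750 nM, range 350 nM to 1600 nM, meaning an expected step of a 1.1-fold lower number from compound 3 to compound 4 (0.04 log units; within the scatter).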

Compound 4, half-maximal effective concentration: < 1000 nM
Compound 4: only a limit was reported; the forecaster's own chance of this, stated with the estimate: 3%; the middle value does not contradict the limit.
By their numbers in this assay, from the lowest: compounds 1, 3 and 2 (each within the scatter of the next, the first and the last beyond it).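

With the 2-fluorophenyl group kept, this position now carries trifluoromethyl as a third group after methyl and methoxy, and compound 4 is reported only as a limit, < 1000 nM. The exchange of methyl for trifluoromethyl on this aromatic carbon reads as an at least 1.5-fold lower number from compound 2 to compound 4 (0.17 log units; that floor lies within the scatter). The steps from compound 3 and from compound 1 cannot be read: the limit of < 1000 nM in this assay, at which 1 of the 4 values shown sits.

On these data alone, the actual value of compound 4 remains open. Also open, as far as these compounds go, is whether an amine, a carboxylic acid or a longer chain such as ethoxy at this position would give a step beyond the scatter.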